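Phenylsulfanyl for sec-butyl on the acylguanidine series

The source may report more compounds than this note shows. Statements on the series, on what has been measured and on what is new or still open speak of the compounds shown alone.

Of the compounds shown here, two have been measured in a functional assay for inhibition of sodium/hydrogen exchanger (Oryctolagus cuniculus); a lower number here means a stronger inhibitor, a higher number a weaker inhibitor. Compound 1 `CCC(C)c1cc(C)c(C(=O)N=C(N)N)cc1S(C)(=O)=O` gives 8 nM in this assay, the lower of the two numbers; compound 2 `Cc1cc(Br)c(C(=O)N=C(N)N)cc1S(C)(=O)=O` gives 70 nM in this assay, and the gap between them lies beyond the scatter. Compound 2 differs from compound 1 in more than one place, so that gap is not a single step. Compound 3 `Cc1cc(Sc2ccccc2)c(S(C)(=O)=O)cc1C(=O)N=C(N)N` has not yet been measured. It differs from compound 1 in one place: phenylsulfanyl in place of sec-butyl on an aromatic carbon. Within the data shown here, no measured pair differs in this way, so the size of the step is not known from the data. A modest move toward a higher number is expected, the step being estimated as a 1.9-fold higher number from compound 1 to compound 3 (0.27 log units; within the scatter), possibly within the scatter. Compound 3 is estimated at 15 nM, with a range from 4 nM to 60 nM.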

Compound 3, half-maximal inhibitory concentration: 14 nM
Estimate against measurement, compound 3: 1.1-fold (0.03 log units) above; measured number inside the range.
By their numbers in this assay, from the lowest: compounds 1 and 3 (each within the scatter of the next); then compound 2.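

In this assay, phenylsulfanyl in place of sec-butyl on this aromatic carbon, ortho to a methylsulfonyl group, gives a 1.8-fold higher number from compound 1 to compound 3 (0.24 log units; within the scatter) and leaves compound 1 and compound 3 indistinguishable. The position can therefore carry a group with a six-membered aromatic ring of carbon only, joined through sulfur, as well as the ring-free sec-butyl, with potency held in the same range. Nothing available accounts for this outcome, and no cause can be assigned to it.

From the compounds shown here alone, whether the sulfur link matters remains open: phenoxy or benzyl on the same aromatic carbon would test this directly. Also open, going by these compounds, is how the position responds to groups of a different kind, such as an amine or a carboxylic acid, in place of phenylsulfanyl.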